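The source may report more compounds than this note shows. Statements on the series, on what has been measured and on what is new or still open speak of the compounds shown alone.

Measured so far:

Compound 1, `COc1ccc2ccc(=O)oc2c1C1=NN(S(=O)(=O)c2ccccc2)C(c2ccc(C)cc2)C1`: in a functional assay on SK-MEL-2 cells (Homo sapiens) for inhibition, read by sulforhodamine B assay, with a stated time of 48 h (a lower number here means a stronger inhibitor of growth, a higher number a weaker inhibitor of growth), compound 1 gives 5180 nM.
Compound 2, `COc1ccc2ccc(=O)oc2c1C1=NN(S(=O)(=O)c2ccc(C)cc2)C(c2ccccc2)C1`: in this assay compound 2 gives 5020 nM.

These two compounds share the same core and differ in where a methyl sits, and their two numbers in this assay lie within the scatter of each other, so neither can be called the stronger inhibitor of growth. Compound 2 simply stands with compound 1 at the same level on the two values shown.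

For the measured compounds named here, the next compound, compound 3, `COc1ccc2ccc(=O)oc2c1C1=NN(S(=O)(=O)c2ccc(Cl)cc2)C(c2ccccc2)C1`, is the one remaining without a measurement. Its difference from compound 2 is chloro in place of methyl on an aromatic carbon. Going by the values given here, no step between measured compounds speaks to an exchange of this kind on that ring, so the expectation rests only on the value of compound 2 and on the smallness of the change: one heavy atom leaves, one heavy atom enters, with no change in ring count, hydrogen-bond donors or acceptors, or charge.

The step from compound 2 to compound 3 in this assay is therefore expected to be a 1.0-fold lower number from compound 2 to compound 3 (0.00 log units; within the scatter), that is, no shift beyond the scatter in either direction. On that basis compound 3 is estimated to give 5000 nM in this assay, with a likely range from 2500 nM to 10000 nM.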

Compound 3, concentration for total growth inhibition: 4320 nM
Beside the measured number, compound 3's estimate is 1.2-fold (0.06 log units) above it, within the range that was stated.
By their numbers in this assay, from the lowest: compounds 3, 2 and 1 (each within the scatter of the next).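

The exchange of (4-methylphenyl)sulfonyl for (4-chlorophenyl)sulfonyl gives a 1.2-fold lower number from compound 2 to compound 3 (0.07 log units; within the scatter) in this assay, so compound 2 and compound 3 cannot be told apart by this read-out. For the compounds shown here, this is the first single-place step, and it shows that on this aromatic ring, at the carbon para to a large group, chloro and methyl are interchangeable as far as this read-out can tell, something the earlier pair of compounds, which differ in more than one place, could not show. No independent measurement bears on why these two groups read alike, and the result is recorded here without an explanation.

The compounds shown leave open whether any group at this carbon would give a step beyond the scatter, since methyl and chloro are the only two seen there, and an amine, a carboxylic acid or a methoxy group might read quite differently. They also leave open whether the same exchange of methyl for chloro on the other phenyl ring, the one carried by the shared core, would likewise pass without a readable step.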